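The compounds below may be only part of what the source reports. "The series", "measured", "known", "first", "only" and "open" are said of these compounds alone.

Notes on the series. In a functional assay on BXPC-3 cells (Homo sapiens) for antiproliferative activity, read by MTT assay, with a stated time of 24 h (a lower number here means a stronger inhibitor, a higher number a weaker inhibitor), compound 1 (`CCn1c(C(=O)NCCCO)ccc1C(CC)(CC)c1ccc(OCS(=O)(=O)c2ccccc2)c(C)c1`) gives 26600 nM and compound 2 (`CCn1c(C(=O)N[C@H](C(=O)O)C(C)C)ccc1C(CC)(CC)c1ccc(OCS(=O)(=O)c2ccccc2)c(C)c1`) gives 16200 nM. Within the data shown here, these are the only two numbers so far, and they lie within the scatter of each other, so compound 2 has no distinct standing yet.

Compound 3 (`CCn1c(C(=O)N[C@@H](CCC(=O)O)C(=O)O)ccc1C(CC)(CC)c1ccc(OCS(=O)(=O)c2ccccc2)c(C)c1`) keeps the shared core and carries 2-carboxyethyl in place of isopropyl on a saturated chain carbon bound to an amide-type nitrogen and a carbonyl carbon.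

Among the measured compounds shown here, the one measured step with any bearing is a 1.6-fold lower number from compound 1 to compound 2 (0.22 log units; within the scatter), which put 1-carboxy-2-methylpropyl in place of 3-hydroxypropyl on an amide-type nitrogen. For the measured compounds named here, it stayed within the scatter and gives only indirect guidance, since no measured step tests this exact change. No step beyond the scatter is therefore expected in this assay, in either direction.

The estimated value for compound 3 is 18000 nM, with an expected range of 8000 nM to 40000 nM. The expected change is a 1.1-fold higher number from compound 2 to compound 3 (0.05 log units; within the scatter).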

Compound 3, half-maximal inhibitory concentration: > 50000 nM
Compound 3 was reported as a limit (the forecaster's own chance of this, stated with the estimate: 10%); middle value at least 2.7-fold (0.44 log units) from the limit.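

In this assay, compound 3 is reported only as a limit, > 50000 nM. Unlike the earlier change on the amide-type nitrogen, 2-carboxyethyl in place of isopropyl on a saturated chain carbon bound to an amide-type nitrogen and a carbonyl carbon gives a step beyond the scatter, an at least 3.0-fold higher number from compound 2 to compound 3 (0.48 log units; beyond the scatter), so the read-out does respond to the group at this position. The comparison with the 3-hydroxypropyl amide is weaker, an at least 1.8-fold higher number from compound 1 to compound 3 (0.27 log units; that floor lies within the scatter), and both steps are floors rather than sizes: the limit of > 50000 nM in this assay, at which 1 of the 3 values shown sits.

The compounds shown do not separate the added carboxylic acid from the longer chain, as 2-carboxyethyl brings both at once. Going by these compounds, a plain propyl chain or a terminal amine at this position would be needed to tell these apart, and how far compound 3 lies beyond its limit remains unknown.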